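Forced swim series: trimethoxyphenyl exchange on compound 2

This account rests on a few compounds, and the source may have more. Where it says the series, first, only, none or still open, it means among the compounds named here.

compound 1 `COc1cc(-c2cc3cc(C4C(C#N)=C(N)OC5=C4C(=O)CCC5)cc(C)c3oc2=O)cc(OC)c1OC`: 5.22%
compound 2 `CCC(C)c1cc(C2C(C#N)=C(N)OC3=C2C(=O)CCC3)cc2cc(-c3ccc(OC)cc3)c(=O)oc12`: 35.1%

Both numbers come from a functional assay on the whole organism (strain Swiss albino) with Mus musculus as the target, in the forced swim test, with a stated time of 5 min, at a dose of 0.5 mg/kg by the intraperitoneal route; on this read-out higher numbers stand for more inhibition at the one dose given (going by the name of the read-out) and lower numbers for less inhibition. Compound 2 stands highest of the two, with compound 1 the nearest and lower by a gap beyond the scatter. For the measured compounds named here, no pair of the measured compounds differs in one place only, so no single step has been measured.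

Compound 3 `CCC(C)c1cc(C2C(C#N)=C(N)OC3=C2C(=O)CCC3)cc2cc(-c3cc(OC)c(OC)c(OC)c3)c(=O)oc12` is not yet measured. It differs from compound 2 as follows: 3,4,5-trimethoxyphenyl in place of 4-methoxyphenyl on an aromatic carbon. Compound 1 also carries a 3,4,5-trimethoxyphenyl and gives the lower number, but it differs from compound 3 in another place too, so its value is only a rough pointer. The expected step in this assay is downward, roughly a number 17.1 percentage points lower from compound 2 to compound 3 (beyond the scatter), and it may reach beyond the scatter. Compound 3 is therefore estimated at 18%, within a range of 3% to 38%.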

Compound 3, a percentage reported as inhibition, in the whole organism at one dose (the size of the read-out at that dose, not a potency): 56.1%
Estimate against measurement, compound 3: 38.1 percentage points below; measured number outside the range, above it.
By their numbers in this assay, from the lowest: compound 1; then compound 2; then compound 3.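

At the aromatic carbon two atoms from the ring oxygen, this assay now gives a single-place reading: 3,4,5-trimethoxyphenyl in place of 4-methoxyphenyl gives a number 21 percentage points higher from compound 2 to compound 3 (beyond the scatter), with sec-butyl held constant. With the 3,4,5-trimethoxyphenyl held constant, sec-butyl in place of methyl gives a number 50.9 percentage points higher from compound 1 to compound 3 (beyond the scatter), so the low value of compound 1 cannot be attributed to the trimethoxyphenyl group, which accompanies the highest value in compound 3. Nothing available explains either step.

Going by these compounds, whether the 3,4,5-trimethoxyphenyl gain carries over to a core bearing methyl remains open, as the step is read only with sec-butyl present. Also open, on these data alone, is how a 4-dimethylaminophenyl group at this position, or a longer chain such as n-hexyl in place of sec-butyl, would read at this single dose.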